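A few compounds are considered here, and "the series" means these few. Any claim that something is new, unique, unknown or untested is made for them only; others in the source may bear on it.

Compound 1 `CCCCCCCCCCCCCCNC(=O)[C@@H]1CSC(c2ccc(OC)c(OC)c2)N1`: 1500 nM
Compound 2 `CCCCCCCCCCCCCCNC(=O)[C@@H]1CSC(c2ccc(NC(C)=O)cc2)N1`: 2300 nM
Compound 3 `CCCCCCCCCCCCCCCNC(=O)[C@@H]1CSC(c2ccc(NC(C)=O)cc2)N1`: 1600 nM

These three values come from a functional assay on cells (Homo sapiens) for antiproliferative activity, read by sulforhodamine B assay, with a stated time of 48 h; a lower number here means a stronger inhibitor, a higher number a weaker inhibitor. Going by the values given here, compound 2 stands within the scatter of both other compounds, so the series so far shows no clear separation. The open question is compound 4 `CCCCCCCCCCCCCCNC(=O)[C@@H]1CSC(c2ccccc2)N1`, which has not yet been measured in this assay. Its difference from compound 2 is hydrogen in place of acetamido on an aromatic carbon. In words, this is hydrogen in place of acetamido on an aromatic carbon, para to a large group.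

The most relevant evidence is a 1.5-fold higher number from compound 1 to compound 2 (0.19 log units; within the scatter). That step exchanges 3,4-dimethoxyphenyl for 4-acetamidophenyl, so it alters the same aryl group, yet it stays within the scatter. The other measured step, a 1.4-fold lower number from compound 2 to compound 3 (0.16 log units; within the scatter), lies in the chain rather than on the aryl group and bears on this change only indirectly. It also stays within the scatter. Among the compounds with values here, no measured compound carries an unsubstituted phenyl, so the removal of acetamido is itself untested. On this limited evidence, no step beyond the scatter is expected in this assay, and no direction can be favoured. The expected change is a 1.2-fold lower number from compound 2 to compound 4 (0.08 log units; within the scatter). For compound 4 the estimated value is 1900 nM, with an expected range of 750 nM to 4800 nM.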

Compound 4, half-maximal inhibitory concentration: 1900 nM
For compound 4 middle estimate and measured number coincide at the digits printed, within the range that was stated.
By their numbers in this assay, from the lowest: compounds 1, 3, 4 and 2 (each within the scatter of the next).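

In this assay, going by these compounds alone, the unsubstituted phenyl of compound 4 gives the first direct reading at this aromatic carbon, para to a large group, and taking away the acetamido there, with its 4 heavy atoms, its hydrogen-bond donor and its hydrogen-bond acceptor, gives a 1.2-fold lower number from compound 2 to compound 4 (0.08 log units; within the scatter) in a step that stays within the scatter. The earlier comparison between compound 1 and compound 2 exchanged one substituted aryl group for another, whereas the reading of a 1.3-fold higher number from compound 1 to compound 4 (0.10 log units; within the scatter) now shows that the bare phenyl also stays within the scatter of the 3,4-dimethoxyphenyl group, so across compounds 1, 2 and 4, which share the same chain, none of these aryl groups separates from the others. No measurement is at hand that would account for this result.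

The compounds shown leave open whether an amine, a carboxylic acid or a chlorine atom at the same aromatic carbon would give a step beyond the scatter. They also leave open whether a much shorter chain on the amide nitrogen would do so, and whether the longer chain of compound 3 would read the same when paired with the bare phenyl.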